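The source may report more compounds than this note shows. Statements on the series, on what has been measured and on what is new or still open speak of the compounds shown alone.

Measured so far:
compound 1 `CC(C)=CCOc1c(C)c(C)c2c(c1C)CCC(C)(COc1ccc(/C=C3\SC(=O)NC3=O)cc1F)O2` — 64%
compound 2 `CC(C)=CCOc1c(C)c(C)c2c(c1C)CCC(C)(COc1ccc(/C=C3\SC(=O)NC3=O)cc1C)O2` — 27%
compound 3 `Cc1c(C)c2c(c(C)c1OC/C=C/c1ccccc1)CCC(C)(COc1ccc(/C=C3\SC(=O)NC3=O)cc1)O2` — 43%

In a functional assay on MCF7 cells (Homo sapiens), tested at 7.5 uM (a higher number here means a weaker effect of the compound at the concentration tested, a lower number a stronger effect), compound 1 gives the highest number of the three, so the weakest effect at the tested concentration: compound 3 sits below it by a gap beyond the scatter, and compound 2 lies furthest below, a difference of a number 37 percentage points lower from compound 1 to compound 2 (beyond the scatter) brought by methyl in place of fluoro on an aromatic carbon.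

Compound 4 `CC(C)=CCOc1c(C)c(C)c2c(c1C)CCC(C)(COc1ccc(/C=C3\SC(=O)NC3=O)cc1)O2` is not yet measured. It differs from compound 1 by hydrogen in place of fluoro on an aromatic carbon. Going by the values given here, the only measured step that touches this position is the one from compound 1 to compound 2, which was large and downward; compound 3, which carries hydrogen at the same place but a different chain on the shared core, has no computed step to compound 1, and its value simply stands well below that of compound 1. Taking the fluoro away is therefore expected to lower the number in this assay, though by less than the methyl step, since compound 3 gives only 43% with hydrogen there. The expected step is a number 19 percentage points lower from compound 1 to compound 4 (beyond the scatter). Compound 4 is estimated at 45%, within 25% to 65%.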

Compound 4, a percentage reported as activity, at one concentration (the size of the read-out at that concentration, not a potency): 5%
The estimate for compound 4 lay 40 percentage points above the measured number; the measured number lies below the stated range.
By their numbers in this assay, from the lowest: compound 4; then compound 2; then compound 3; then compound 1.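

Hydrogen on this aromatic carbon gives the lowest number of the four in this assay and so the strongest effect at the tested concentration: the step with fluoro leaving is a number 59 percentage points lower from compound 1 to compound 4 (beyond the scatter) and the step with methyl leaving is a number 22 percentage points lower from compound 2 to compound 4 (beyond the scatter) so neither fluoro nor methyl at this place matches hydrogen, and the earlier drop on going from fluoro to methyl no longer reads as a gain from methyl itself. With hydrogen held at this place the chain also counts, since 2-methylprop-1-en-1-yl in place of 2-phenylethenyl gives a number 38 percentage points lower from compound 3 to compound 4 (beyond the scatter) and the low number belongs to this pairing of chain and hydrogen alone among the compounds shown.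

Open, going by these compounds, is how a chlorine, a methoxy group or a hydroxyl at this place would compare with hydrogen. Also open, on these data alone, is whether fluoro or methyl would raise the number in the same way with the 2-phenylethenyl chain. No measurement at hand accounts for any of these steps.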